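The source may hold more compounds than are shown below. What is called first, only, known or untested is meant among the compounds shown, and "the series" means these compounds.

Compound 1 `Cc1ccc(N2C(=O)COc3ccc(-c4cnc5ccccc5c4)cc32)cc1` — > 40000 nM
Compound 2 `CC(C)N1C(=O)COc2ccc(-c3cccc(NS(=O)(=O)c4ccc(F)cc4)c3)cc21` — > 40000 nM

Of the compounds shown here, two sharing one core have been measured, and neither gives a number. In a functional assay on A-375 cells (Homo sapiens) for antiproliferative activity, read by MTT assay, with a stated time of 72 h (a higher number here means a weaker inhibitor, a lower number a stronger inhibitor), compound 1 reaches only the assay limit of > 40000 nM. In this assay compound 2 likewise reaches only a limit, > 40000 nM. Within the data shown here, compound 2 therefore has no place on a scale of numbers: its own result is a limit, and the one further value shown is a limit as well, so no order between the two can be read (the limit of > 40000 nM in this assay, at which 2 of the 2 values shown sit).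

Compound 3 `O=C1COc2ccc(-c3cccc(NS(=O)(=O)c4ccc(F)cc4)c3)cc2N1C1CCCCC1` has not yet been measured. It differs from compound 2 in one place (cyclohexyl in place of isopropyl on an amide-type nitrogen in a ring). Among the measured compounds shown here, no step between measured compounds is available, so the size of this change in this assay is unknown; the expectation is for no step beyond the scatter. Compound 3 is expected to give 50000 nM, in the range 15000 nM to 150000 nM. The expected step is a step that the limit leaves unreadable from compound 2 to compound 3.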

Compound 3, half-maximal inhibitory concentration: 23800 nM
The estimate for compound 3 lay 2.1-fold (0.32 log units) above the measured number, and the stated range covers the measured number.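

Compound 3 is the first of the compounds shown to give a number rather than a limit in this assay, so this amide-type nitrogen now has one readable point, at 23800 nM. Cyclohexyl in place of isopropyl gives an at least 1.6-fold lower number from compound 2 to compound 3 (0.22 log units; that floor lies within the scatter), so the change can be stated only as a floor, and that floor does not establish a real gain. The full size of the step cannot be read, since the result for compound 2 is a limit: the limit of > 40000 nM in this assay, at which 2 of the 3 values shown sit.

Going by these compounds, it remains open whether the ring itself matters or simply the larger carbon group, which a cyclopentyl ring or a straight hexyl chain on this nitrogen would help to separate. Also open, on these data alone, is whether an amine on the cyclohexyl ring would keep a readable number in this assay.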